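The source may report more compounds than this note shows. Statements on the series, on what has been measured and on what is new or still open speak of the compounds shown alone.

Working notes on the sulfonate series.

Compound 3 `CCC(=O)Nc1ccc(S(=O)(=O)Oc2ccccc2I)cc1` gives 8100 nM in a functional assay on MCF7 cells (Homo sapiens) for antiproliferative activity, read by sulforhodamine B assay, with a stated time of 48 h; a higher number here means a weaker inhibitor, a lower number a stronger inhibitor. The two earlier compounds sit close by: compound 2 `CCC(=O)Nc1ccc(S(=O)(=O)Oc2ccccc2C(C)C)cc1` gives 11000 nM and compound 1 `CC(=O)Nc1ccc(S(=O)(=O)Oc2ccccc2C(C)C)cc1` gives 16000 nM. Among the compounds with values here, both steps so far, a 1.5-fold lower number from compound 1 to compound 2 (0.16 log units; within the scatter) and a 1.4-fold lower number from compound 2 to compound 3 (0.13 log units; within the scatter), are within the scatter, so the three numbers cannot be set apart from one another, and compound 3 is simply one of three compounds that behave alike in this assay.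

The next compound, compound 4 `CCCCCNC(=O)Nc1ccc(S(=O)(=O)Oc2ccccc2I)cc1`, keeps the iodo-bearing sulfonate of compound 3 and changes the acyl end: pentylamino in place of ethyl on a carbonyl carbon. Within the data shown here, only one measured step touches this end of the molecule, a 1.5-fold lower number from compound 1 to compound 2 (0.16 log units; within the scatter), and that was a small growth of the chain that stayed within the scatter. Among the measured compounds shown here, no measured step brings an amide-type nitrogen or a hydrogen-bond donor to the carbonyl carbon, so the present change has no direct precedent. The expectation is therefore a step of no more than the scatter, a 1.2-fold lower number from compound 3 to compound 4 (0.10 log units; within the scatter), with wide uncertainty.

Compound 4 is expected to give about 6500 nM in this assay, within a range of 2500 nM to 17000 nM.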

Compound 4, half-maximal inhibitory concentration: 5400 nM
Beside the measured number, compound 4's estimate is 1.2-fold (0.08 log units) above it; the measured number falls inside the stated range.
By their numbers in this assay, from the lowest: compounds 4, 3, 2 and 1 (each within the scatter of the next, the first and the last beyond it).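

In this assay, the carbonyl carbon whose other neighbour is the amide-type nitrogen takes pentylamino in place of ethyl, a change that adds a nitrogen, a hydrogen-bond donor and a longer chain, and the outcome is a 1.5-fold lower number from compound 3 to compound 4 (0.18 log units; within the scatter). Within the data shown here, the only earlier step at this end, a 1.5-fold lower number from compound 1 to compound 2 (0.16 log units; within the scatter), was the addition of a single methyl with isopropyl on the other side of the molecule; the present step shows that a much larger replacement, carrying the amide hydrogen, also stays within the scatter when iodo is present. No independent measurement bears on why this end of the molecule accepts the change.

Still open, from the compounds shown here alone, is whether a longer chain than pentylamino, a cyclohexylamino group, or a pentyl chain ending in an amine or a carboxylic acid would move the number beyond the scatter. Also open, going by these compounds, is whether pentylamino would give a similar number with isopropyl in place of iodo, and whether the nitrogen or the chain contributes more to this small step.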